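A benzyl swap on a compound held at a limit

This account rests on a few compounds, and the source may have more. Where it says the series, first, only, none or still open, it means among the compounds named here.

Measured in a functional assay on PC-3 cells (Homo sapiens) for cytotoxicity, read by MTT assay; on this read-out higher numbers stand for weaker inhibition and lower numbers for stronger inhibition:
compound 1 `COc1ccc2cc([C@H](C)c3nnc(SCc4ccc(Cl)cc4)n3-c3ccc(F)cc3)ccc2c1` gives <= 400000 nM (a limit)
compound 2 `COc1ccc(CSc2nnc([C@@H](C)c3ccc4cc(OC)ccc4c3)n2-c2ccc(Cl)cc2)cc1` gives <= 400000 nM (a limit)
compound 3 `COc1ccc2cc([C@H](C)c3nnc(SCc4ccc(Cl)cc4)n3-c3ccc(Cl)cc3)ccc2c1` gives 5800 nM (a number)

Compound 1 stands at <= 400000 nM as a limit and not as a number. Most of this small set rests on the limit of <= 400000 nM in this assay, at which 2 of the 3 values shown sit, and only one compound has a true number.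

Compound 4 `COc1ccc2cc([C@H](C)c3nnc(SCc4c(C)cc(C)cc4C)n3-c3ccc(F)cc3)ccc2c1` keeps the fluoro of compound 1 and differs by 2,4,6-trimethylphenyl in place of 4-chlorophenyl on a saturated chain carbon bound to a sulfur with 2,4,6-trimethylphenyl in place of 4-chlorophenyl on a saturated chain carbon bound to a sulfur.

Among the measured compounds shown here, two measured steps bear on this change. One is a step that the limit leaves unreadable from compound 1 to compound 3 with chloro in place of fluoro on an aromatic carbon. The other is a step that the limit leaves unreadable from compound 2 to compound 3 with chloro in place of methoxy on an aromatic carbon. For the measured compounds named here, neither size can be read, and no measured compound carries the new group. Compound 3 at 5800 nM shows that a true number is possible in this assay for this family, so some move toward stronger inhibition can be expected, though only loosely. The expected step is a step that the limit leaves unreadable from compound 1 to compound 4 and it is a rough estimate. The estimate for compound 4 is 60000 nM with an expected range from 6000 nM to 400000 nM and a real chance that the outcome is only a limit.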

Compound 4, half-maximal inhibitory concentration: 43300 nM
Compound 4: the middle estimate sits 1.4-fold (0.14 log units) above what was measured; the measured number falls inside the stated range.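

Among the compounds shown here, the change from compound 1 to compound 4 gives no step of readable size, because compound 1 stands at a limit and not at a number: the limit of <= 400000 nM in this assay, at which 2 of the 4 values shown sit. The compounds shown leave open how much 2,4,6-trimethylbenzyl in place of 4-chlorobenzyl changes the cytotoxic strength when both partners carry a true number.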